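The source may report more compounds than this note shows. Statements on the series, on what has been measured and on what is new or still open speak of the compounds shown alone.

Among the measured compounds shown here, in a functional assay on the whole organism (strain Kunming) with Mus musculus as the target, in the formalin test, with a stated time of 0.5 h (a higher number here means that more compound is needed for the effect, a lower number that less compound is needed), compound 1 `COc1cc(OC)c(OC)cc1/C=C/COC(=O)/C=C/c1ccc(OC)c(OC)c1` gives 225 umol/kg, the only actual number so far. Compound 2 `COc1cc(OC)c(OC)cc1/C=C/COC(=O)/C=C/c1c(OC)ccc(OC)c1OC` gives only a limit, >= 180 umol/kg. Compound 1 therefore has no measured neighbour to be ranked against. Compound 3 `COc1cc(OC)c(OC)cc1/C=C/COC(=O)/C=C/c1cccc(Br)c1` keeps the core of compound 1 but carries 3-bromophenyl in place of 3,4-dimethoxyphenyl on a double-bonded chain carbon bound to a double-bonded chain carbon. For the measured compounds named here, no two measured compounds differ in just one place, so nothing yet shows how far such an exchange moves the dose. With compound 1 at 225 umol/kg as the sole anchor, the expected step in this assay is none beyond the usual scatter, with no favoured direction. The estimated step is a 1.1-fold lower number from compound 1 to compound 3 (0.05 log units; within the scatter). Compound 3 is expected at 200 umol/kg, with an estimated range from 90 umol/kg to 420 umol/kg.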

Compound 3, dose for half-maximal effect: 260 umol/kg
Beside the measured number, compound 3's estimate is 1.3-fold (0.11 log units) below it; the measured number falls inside the stated range.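

Among the compounds shown here, the exchange of 3,4-dimethoxyphenyl for 3-bromophenyl gives the first step that can be read in this assay: a 1.2-fold higher number from compound 1 to compound 3 (0.06 log units; within the scatter). At this place, on a double-bonded chain carbon bound to a double-bonded chain carbon, a group with hydrogen-bond acceptors and one with none therefore give doses that cannot be told apart, although this is a single exchange and not a rule. Compound 2 stands only as a limit, so it adds no further step: the limit of >= 180 umol/kg in this assay, at which 1 of the 3 values shown sits.

From the compounds shown here alone, whether a group of another kind at this place, such as an amine or a carboxylic acid, would move the dose beyond the scatter remains open. Also open, going by these compounds, is whether a change elsewhere on the shared core would matter more than this one.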